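Tetrazole for Carboxylic Acid on a Weak Kynurenine Monooxygenase Inhibitor

The source may hold more compounds than are shown below. What is called first, only, known or untested is meant among the compounds shown, and "the series" means these compounds.

Of the compounds shown here, three have been measured in an assay on isolated protein for inhibition of kynurenine 3-monooxygenase (Rattus norvegicus); on this read-out higher numbers stand for weaker inhibition and lower numbers for stronger inhibition. Compound 1 `Cc1ccc(S(=O)(=O)Nc2nc(-c3cccc([N+](=O)[O-])c3)cs2)cc1` gives 48 nM, and compound 3 `O=[N+]([O-])c1cccc(-c2csc(NS(=O)(=O)c3ccccc3)n2)c1` gives 200 nM. Compound 2 `O=C(O)c1cc(-c2cccc([N+](=O)[O-])c2)on1`, built on a different core, gives 2680 nM, the highest of the three numbers and therefore the weakest inhibitor; its gap to the nearest neighbour, compound 3, and to the furthest, compound 1, lie beyond the usual scatter in each case.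

Compound 4 `O=[N+]([O-])c1cccc(-c2cc(-c3nn[nH]n3)no2)c1` keeps the core of compound 2 and differs from it in one place: 2H-tetrazol-5-yl in place of carboxy on an aromatic carbon. Within the data shown here, no measured pair shows this kind of exchange. Among the measured compounds shown here, the only step that has been measured, a 4.2-fold higher number from compound 1 to compound 3 (0.62 log units; beyond the scatter), concerns the loss of a methyl on a different core and says nothing about swapping an acid for a tetrazole. Without a comparable step, the expectation for compound 4 is anchored on compound 2 alone, with a wide range to reflect the uncertainty. Compound 4 is thus expected to remain a weak inhibitor, with a step of a 1.3-fold lower number from compound 2 to compound 4 (0.13 log units; within the scatter) that is estimated to stay within the scatter. For compound 4 the estimate in this assay is 2000 nM, in a range from 500 nM to 8000 nM.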

Compound 4, half-maximal inhibitory concentration: 1160 nM
Beside the measured number, compound 4's estimate is 1.7-fold (0.24 log units) above it; low and high end bracket the measured number.
By their numbers in this assay, from the lowest: compound 1; then compound 3; then compound 4; then compound 2.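

In this assay, among these compounds, 2H-tetrazol-5-yl in place of carboxy gives a 2.3-fold lower number from compound 2 to compound 4 (0.36 log units; beyond the scatter), the first measured change on the aromatic carbon next to the ring nitrogen. The step is modest, but it shows that inhibition on this core does not depend on keeping carboxy at this place: a larger group, with 5 heavy atoms instead of 3 and one five-membered aromatic ring of its own, is tolerated and gives somewhat stronger inhibition. No available measurement explains why the number moves in this direction.

Among the compounds shown here, with only two groups compared at this place, it remains open whether a primary amide or a methyl ester there would hold the inhibition or lose it. From the compounds shown here alone, it is also open whether the exchange of carboxy for 2H-tetrazol-5-yl would give a similar step on another core, such as that of compound 1, so the result describes one position on one core and is not a general rule.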